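The compounds below may be only part of what the source reports. "The series", "measured", "known", "first", "only" and "open" are said of these compounds alone.

Compound 1 `COc1ccc(/C=C\c2cc(OC)c(OC)c(OC)c2)cc1OCc1ccc(CN2CCCC[C@H]2C(=O)O)cc1` is the reference point of this step. In a functional assay on B16-F10 cells (Mus musculus) for antiproliferative activity, read by CCK-8 assay, with a stated time of 48 h (a lower number here means a stronger inhibitor, a higher number a weaker inhibitor), compound 1 gives > 10000 nM, which is a limit of the assay and not a measured number (the limit of > 10000 nM in this assay, at which 1 of the 2 values shown sits). Compound 2 `COc1ccc(/C=C\c2cc(OC)c(OC)c(OC)c2)cc1OCc1ccc(CN2CCCCC2C(=O)NCCN)cc1` differs from compound 1 in a single place, and in this assay compound 2 gives 4600 nM. Going by the values given here, the only measured step available is an at least 2.1-fold lower number from compound 1 to compound 2 (0.33 log units; beyond the scatter), in which 2-((2-aminoethyl)carbamoyl)piperidin-1-yl replaces 2-carboxypiperidin-1-yl.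

Compound 3 `COc1ccc(/C=C\c2cc(OC)c(OC)c(OC)c2)cc1OCc1ccc(C=O)cc1` has not yet been measured. It differs from compound 1 by formyl in place of (2-carboxypiperidin-1-yl)methyl on an aromatic carbon. The measured step does not cover this change: it alters the group on the six-membered non-aromatic ring, whereas here that ring is removed altogether. Compound 1 sits only at a limit, so the starting point itself is uncertain. Compound 3 is therefore expected to show a step of an at least 4.0-fold lower number from compound 1 to compound 3 (0.60 log units; beyond the scatter) in this assay, in the direction of a lower number. The estimate for compound 3 is 2500 nM, with a range from 300 nM to 15000 nM.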

Compound 3, half-maximal inhibitory concentration: 4200 nM
Compound 3: the middle estimate sits 1.7-fold (0.23 log units) below what was measured, and the stated range covers the measured number.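

Replacing the entire group, ring included, gives an at least 2.3-fold lower number from compound 1 to compound 3 (0.37 log units; beyond the scatter) in this assay, so the six-membered non-aromatic ring is not required at this aromatic carbon for a measurable value. The size of this step is bounded on one side only, as compound 1 sits at a limit: the limit of > 10000 nM in this assay, at which 1 of the 3 values shown sits. Compound 2 gives 4600 nM and compound 3 gives 4200 nM, values within the usual scatter of each other, so the small formyl and the large 2-((2-aminoethyl)carbamoyl)piperidin-1-yl-bearing group are not separated in this assay.

On these data alone, it remains open whether a primary amine or a carboxylic acid placed at this aromatic carbon without the ring would match formyl. As far as these compounds go, it is also open whether a longer chain on the amide of compound 2 would shift the value.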